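The source may hold more compounds than are shown below. What is called first, only, known or untested is meant among the compounds shown, and "the series" means these compounds.

Compound 1 `CC(C)N1CC2(CCN(C(=O)Nc3cc(F)cc(F)c3)CC2)C1c1ccc(F)cc1`: 172 nM
Compound 2 `CC[C@H](C)[C@H](NC(=O)N1CCC2(CC1)C(=O)N(c1cccc(F)c1)C2c1ccc(Cl)cc1)C(=O)OC(C)C`: 45 nM

Both numbers come from an assay on HEK293 cells for inhibition of Voltage-dependent T-type calcium channel subunit alpha-1H (Homo sapiens), read by patch clamp, using a membrane potential dye; a lower number here means a stronger inhibitor, a higher number a weaker inhibitor. Compound 2 stands at the lower of the two numbers; the gap to compound 1 lies beyond the usual scatter. Compound 3 `CCC(C)NC(=O)N1CCC2(CC1)C(=O)N(c1cccc(F)c1)C2c1ccc(Cl)cc1` differs from compound 2 by a group of 4 heavy atoms (4 carbon; no ring) in place of a group of 11 heavy atoms (9 carbon, 2 oxygen; no ring), on an amide-type nitrogen, so a small chain stands where a larger chain stood. For the measured compounds named here, no measured pair shows a change of this kind, so the expectation rests on the change alone: a moderate rise in this assay is expected, a 3.3-fold higher number from compound 2 to compound 3 (0.52 log units; beyond the scatter). Compound 3 is therefore expected to give about 150 nM, in the range 40 nM to 600 nM.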

Compound 3, half-maximal inhibitory concentration: 1250 nM
For compound 3 the middle estimate is 8.3-fold (0.92 log units) below the measured one; measured number outside the range, above it.
By their numbers in this assay, from the lowest: compound 2; then compound 1; then compound 3.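

At this position, on an amide-type nitrogen, the size of the step in this assay shows that the group is far from a passive attachment: replacing the chain of 11 heavy atoms with sec-butyl gives a 28-fold higher number from compound 2 to compound 3 (1.44 log units; beyond the scatter), which is large and beyond the scatter. Compound 1 could not show this, as it differs from compound 2 in more than one place. No available evidence identifies which feature of the lost chain matters.

Still open, from the compounds shown here alone, is whether a carboxylic acid or a simple longer alkyl chain on this nitrogen would restore the lower number of compound 2.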